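Aryl exchange on compound 3 at the assay limit

A few compounds are considered here, and "the series" means these few. Any claim that something is new, unique, unknown or untested is made for them only; others in the source may bear on it.

Values in an ADME assay on KB cells (Homo sapiens) for cytotoxicity, read by MTT assay, with a stated time of 72 h (a higher number here means a weaker inhibitor, a lower number a stronger inhibitor), all of them limits:
- compound 1 `COc1ccc(C2=C(c3cc(OC)c(OC)c(OC)c3)C(=O)CC2O[SiH2]C(C)(C)C)cc1`: > 100 ug/mL
- compound 2 `COc1cc(C2=C(c3cc(C)c(OC)c(C)c3)C(OC(C)=O)CC2=O)cc(OC)c1OC`: > 100 ug/mL
- compound 3 `COc1cc(C2=C(c3ccccc3)C(O[SiH2]C(C)(C)C)CC2=O)cc(OC)c1OC`: > 100 ug/mL

Compound 3 stands at a limit, > 100 ug/mL, so no number is known for it. The series as a whole offers only (the limit of > 100 ug/mL in this assay, at which 3 of the 3 values shown sit). Within the data shown here, the single measured step, a step that the two limits leave unreadable from compound 1 to compound 3, gives no size. Compound 4 `COc1cc(C2=C(c3cc(C)c(OC)c(C)c3)C(O[SiH2]C(C)(C)C)CC2=O)cc(OC)c1OC` carries 4-methoxy-3,5-dimethylphenyl in place of phenyl on a double-bonded ring carbon. Compound 2 bears the same 4-methoxy-3,5-dimethylphenyl, and its > 100 ug/mL is also a limit. No step beyond the scatter is therefore expected in this assay, and another report at the limit is the likeliest outcome. The estimated step is a number no higher from compound 3 to compound 4 (the limit leaves the size open). For compound 4 the estimated value is 100 ug/mL, with an expected range from 30 ug/mL to 200 ug/mL.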

Compound 4, half-maximal inhibitory concentration: 40 ug/mL
Compound 4: middle estimate off by 2.5-fold (0.40 log units), on the high side; the range from low to high includes it.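

In this assay, among these compounds, 4-methoxy-3,5-dimethylphenyl in place of phenyl on a double-bonded ring carbon gives the first readable change: an at least 2.5-fold lower number from compound 3 to compound 4 (0.39 log units; beyond the scatter). The aryl group alone does not account for this, as a group of 5 heavy atoms in place of a group of 3 heavy atoms on an oxygen on a saturated carbon also gives a readable step: an at least 2.5-fold lower number from compound 2 to compound 4 (0.39 log units; beyond the scatter). Against 4-methoxyphenyl, the same aryl group also reads: an at least 2.5-fold lower number from compound 1 to compound 4 (0.39 log units; beyond the scatter).

From the compounds shown here alone, the true sizes of these steps stay open, since only compound 4 has a number: the limit of > 100 ug/mL in this assay, at which 3 of the 4 values shown sit. Going by these compounds, whether an amine in place of the methoxy of 4-methoxy-3,5-dimethylphenyl would keep this activity also stays open.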